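The source may report more compounds than this note shows. Statements on the series, on what has been measured and on what is new or still open speak of the compounds shown alone.

Working notes on the series.

Compound 1 `CCCn1c(=O)[nH]c2nc(-c3ccc(S(=O)(=O)N4CCN(Cc5ccc(Br)cc5)CC4)cc3)[nH]c2c1=O` is the reference point. In an assay on CHO cells for displacement of a labelled ligand from adenosine receptor A2b (Homo sapiens), read by scintillation counting, with a stated time of 75 min, in the presence of a further agent that is not named here (on this read-out higher numbers stand for weaker inhibition and lower numbers for stronger inhibition), compound 1 gives 0.153 nM, the lowest of the two numbers recorded so far. Among the compounds with values here, the nearest neighbour is compound 2 `CCCn1c(=O)c2[nH]c(-c3ccc(S(=O)(=O)N4CCN(c5ccc(Cl)cc5)CC4)cc3)nc2n(C)c1=O`, which in this assay gives 1.91 nM, a higher number that falls beyond the usual scatter; compound 2 differs from compound 1 at more than one place, so no single step between them is defined.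

Compound 3 `CCCn1c(=O)[nH]c2nc(-c3ccc(S(=O)(=O)N4CCN(c5ccc(F)cc5)CC4)cc3)[nH]c2c1=O` has not yet been measured in this assay. Relative to compound 1 the change is 4-fluorophenyl in place of 4-bromobenzyl on an amine nitrogen in a ring. Within the data shown here, no measured pair isolates this change, so the size of the step rests on judgement. Compound 2, which also bears an aryl group directly on the ring nitrogen, gives the higher number in this assay, but it carries a further difference in the core, so only a loose reading is possible.

The expected step is a 3.3-fold higher number from compound 1 to compound 3 (0.51 log units; beyond the scatter), a modest move toward weaker inhibition, though not far beyond the scatter. In this assay compound 3 is estimated at 0.5 nM, with a range from 0.12 nM to 2 nM.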

Compound 3, inhibition constant: 0.644 nM
Estimate against measurement, compound 3: 1.3-fold (0.11 log units) below; measured number inside the range.
By their numbers in this assay, from the lowest: compound 1; then compound 3; then compound 2.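

Within the data shown here, the step of a 4.2-fold higher number from compound 1 to compound 3 (0.62 log units; beyond the scatter) gives the first single-change reading at this position, on an amine nitrogen in a ring, in this assay. It shows that 4-fluorophenyl in place of 4-bromobenzyl on the shared core moves the number toward weaker inhibition by a modest amount, a shift that lies beyond the usual scatter. Among these compounds, nothing at hand accounts for the size of this step, and the single change alters both the group attached to the nitrogen and its halogen, so the step cannot be divided between the two.

The compounds shown leave open which part of the change carries the step, as neither 4-fluorobenzyl nor 4-bromophenyl appears on this nitrogen with the core of compound 1. Also open, on these data alone, is how the number responds at this position to groups without an aromatic ring, such as a simple alkyl chain or a chain ending in a carboxylic acid.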